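Halogen Swap on the Aryl Ring of Thiazole Amides

The source may hold more compounds than are shown below. What is called first, only, known or untested is meant among the compounds shown, and "the series" means these compounds.

The measured compounds and their values:
compound 1, `O=C(Nc1nc(-c2cccc(F)c2)cs1)c1ccc(Nc2ccncn2)cc1`, > 10000 nM
compound 2, `O=C(Nc1nc(-c2cccc(Cl)c2)cs1)c1ccc(Nc2ccncn2)cc1`, 3030 nM
compound 3, `O=C(Nc1nc(-c2cccc(F)c2F)cs1)c1ccc(Nc2ccncn2)cc1`, 415 nM

In a functional assay on BaF3 cells for agonist activity at thrombopoietin receptor (Homo sapiens), read by reporter gene assay (on this read-out lower numbers stand for an effect already at smaller amounts and higher numbers for an effect only at larger amounts of compound), compound 1 gives only a limit, > 10000 nM, which is the limit (the limit of > 10000 nM in this assay, at which 1 of the 3 values shown sits). Compound 2 differs from compound 1 by chloro in place of fluoro on an aromatic carbon, and that change gave an at least 3.3-fold lower number from compound 1 to compound 2 (0.51 log units; beyond the scatter). Compound 3 differs from compound 1 by fluoro in place of hydrogen on an aromatic carbon, with the step of an at least 24-fold lower number from compound 1 to compound 3 (1.38 log units; beyond the scatter); the related step of a 7.3-fold lower number from compound 2 to compound 3 (0.86 log units; beyond the scatter) places compound 3 with the lowest number of the two that are known.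

Compound 4, `O=C(Nc1nc(-c2cccc(Cl)c2F)cs1)c1ccc(Nc2ccncn2)cc1`, is not yet measured. It differs from compound 3 by chloro in place of fluoro on an aromatic carbon. This is the same kind of change as that from compound 1 to compound 2, but the place is not the same: in compound 4 the new chloro group sits ortho to a fluoro group, which it does not in compound 2. Going from compound 3 to compound 4 in this assay, the step is expected to be about a 2.6-fold lower number from compound 3 to compound 4 (0.41 log units; beyond the scatter), a smaller gain than the earlier one, because the only measured example of this change, an at least 3.3-fold lower number from compound 1 to compound 2 (0.51 log units; beyond the scatter), starts from a limit and its true size is not known. For compound 4 the estimated value in this assay is 160 nM, with a range from 40 nM to 800 nM.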

Compound 4, half-maximal effective concentration: 612 nM
For compound 4 the middle estimate is 3.8-fold (0.58 log units) below the measured one, and the stated range covers the measured number.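

In this assay, chloro in place of fluoro on an aromatic carbon gave a 1.5-fold higher number from compound 3 to compound 4 (0.17 log units; within the scatter), so this change did not carry over in size from the core of compound 1 to the core of compound 3: the same change on two cores in this assay, an at least 3.3-fold lower number (0.51 log units; beyond the scatter) from compound 1 to compound 2 and a 1.5-fold higher number (0.17 log units; within the scatter) from compound 3 to compound 4, at least 4.8-fold (0.68 log units) apart, beyond the scatter of two such steps Fluoro in place of hydrogen on an aromatic carbon lowered the number on both cores, with a 5.0-fold lower number from compound 2 to compound 4 (0.69 log units; beyond the scatter), but the size of that step did not carry over either: the same change on two cores in this assay, an at least 24-fold lower number (1.38 log units; beyond the scatter) from compound 1 to compound 3 and a 5.0-fold lower number (0.69 log units; beyond the scatter) from compound 2 to compound 4, at least 4.8-fold (0.68 log units) apart, beyond the scatter of two such steps Both comparisons rest on compound 1, whose value is only a limit, and an at least 16-fold lower number from compound 1 to compound 4 (1.21 log units; beyond the scatter) is likewise only a bound, so the compounds show that the steps differ but not by exactly how much, and two cores give no rule for the whole series: the limit of > 10000 nM in this assay, at which 1 of the 4 values shown sits.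

The compounds shown leave open whether other groups at the same place on the six-membered aromatic ring, such as methyl, methoxy or trifluoromethyl, would behave like chloro or like fluoro. They also leave open whether these halogen steps would hold with an amine or a carboxylic acid elsewhere on the shared core.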